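A second 5-(nitrooxy)pentyl on compound 2

This account rests on a few compounds, and the source may have more. Where it says the series, first, only, none or still open, it means among the compounds named here.

Two measured compounds frame this step. In a functional assay on A549 cells (Homo sapiens) for cytotoxicity, read by resazurin assay, with a stated time of 72 h (a lower number here means a stronger inhibitor, a higher number a weaker inhibitor), compound 2 `COc1cc(/C=C/C(=O)OCCCCCO[N+](=O)[O-])ccc1O` gives 6390 nM as the higher of the two numbers, and compound 1 `O=C(/C=C/c1ccc(OCCCCCO[N+](=O)[O-])c(O)c1)OCCCCCO[N+](=O)[O-]` gives 450 nM as the lower, a gap beyond the scatter. Among the measured compounds shown here, these two differ in more than one place, so no measured pair isolates the change at issue. Compound 3 `COc1cc(/C=C/C(=O)OCCCCCO[N+](=O)[O-])ccc1OCCCCCO[N+](=O)[O-]` arises from compound 2 by a single change (5-(nitrooxy)pentyl in place of hydrogen on an oxygen on an aromatic ring), with 5-(nitrooxy)pentyl in place of hydrogen on an oxygen on an aromatic ring. A drop is expected because compound 1 at 450 nM also carries 5-(nitrooxy)pentyl on an oxygen on an aromatic ring. The expected size is a 5.3-fold lower number from compound 2 to compound 3 (0.73 log units; beyond the scatter) as a working estimate. In this assay the expected value for compound 3 is 1200 nM within a range of 300 nM to 4500 nM (estimated).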

Compound 3, half-maximal inhibitory concentration: > 50000 nM
Compound 3 ended at the assay's limit; the forecaster's own chance of this, stated with the estimate: 3%; middle value at least 41-fold (1.61 log units) from the limit.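

In this assay compound 3 stands at a limit and not at a number: the limit of > 50000 nM in this assay, at which 1 of the 3 values shown sits.

5-(nitrooxy)pentyl in place of hydrogen on this oxygen gives an at least 7.8-fold higher number from compound 2 to compound 3 (0.89 log units; beyond the scatter), so with methyl on the second aromatic oxygen the chain brings no lower number in this assay. Methyl in place of hydrogen on an oxygen on an aromatic ring, with the chain held in place, gives an at least 110-fold higher number from compound 1 to compound 3 (2.04 log units; beyond the scatter), so in these compounds the outcome of the chain depends on what the second oxygen carries.

Still open, going by these compounds, is whether a shorter chain, a longer chain or a chain ending in an amine on this oxygen would behave as 5-(nitrooxy)pentyl does. Also open, on these data alone, is whether the nitrooxy end or the pentyl chain governs the step, and whether ethyl in place of methyl would give the same result.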